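The source may hold more compounds than are shown below. What is called first, only, known or untested is meant among the compounds shown, and "the series" means these compounds.

Measured compounds in an assay on CHO-K1 cells for displacement of a labelled ligand from prostaglandin E2 receptor EP1 subtype (Homo sapiens); a higher number here means a weaker inhibitor, a lower number a stronger inhibitor:

Compound 1 `Cc1cc(C(=O)NN2CCCCC2)nn1Cc1cc(Cl)ccc1OCC(C)C` gives 200 nM
Compound 2 `Cc1cc(NC(=O)C2CCCCC2)nn1Cc1cc(Cl)ccc1OCC(C)C` gives 31.6 nM
Compound 3 `Cc1cc(NC(=O)OC(C)(C)C)nn1Cc1cc(Cl)ccc1OCC(C)C` gives 31.6 nM

Compound 3 stands level with compound 2 at the digits printed, and the two share the lowest number of the three; compound 1 sits above them, as the step of a 6.3-fold lower number from compound 1 to compound 3 (0.80 log units; beyond the scatter) shows. Compound 4 `Cc1cc(NC(=O)OC(C)(C)C(F)(F)F)nn1Cc1cc(Cl)ccc1OCC(C)C` is the next compound to be measured. It differs from compound 3 in one place: trifluoromethyl in place of methyl on a saturated chain carbon bound to an oxygen next to a carbonyl group and two saturated chain carbons.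

Among the compounds with values here, none of the measured steps touches this part of the molecule. The nearest guide is the step of no change at the digits printed from compound 2 to compound 3 (within the scatter), in which the whole group on the carbonyl carbon was exchanged without any shift in the numbers, and the two larger steps of a 6.3-fold lower number from compound 1 to compound 2 (0.80 log units; beyond the scatter) and a 6.3-fold lower number from compound 1 to compound 3 (0.80 log units; beyond the scatter) concern a different part of the molecule altogether. Since a complete swap of that group left the number unchanged, a smaller alteration within it is expected to produce at most a step within the scatter, with no clear direction, so the estimated step of no change at the digits printed from compound 3 to compound 4 (within the scatter) is small. Compound 4 is therefore expected to give about 31.6 nM in this assay, most likely between 10 nM and 100 nM.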

Compound 4, half-maximal inhibitory concentration: 50.1 nM
The estimate for compound 4 lay 1.6-fold (0.20 log units) below the measured number; the range from low to high includes it.
By their numbers in this assay, from the lowest: compounds 2, 3 and 4 (each within the scatter of the next); then compound 1.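

In this assay, trifluoromethyl in place of methyl on the tert-butoxy group gives a 1.6-fold higher number from compound 3 to compound 4 (0.20 log units; within the scatter), so this change, made inside the group rather than by replacing all of it, leaves no readable mark on the result. The wider exchange gives a 1.6-fold higher number from compound 2 to compound 4 (0.20 log units; within the scatter), which means that cyclohexyl, tert-butoxy and 1-methyl-1-(trifluoromethyl)ethoxy on this carbonyl carbon cannot be told apart in this assay, at least among these three compounds. No measurement is available that would explain why these groups give such similar results.

The compounds shown leave open how far this flat picture extends, since all three groups on the carbonyl carbon are built on saturated carbon and none carries an amine, a carboxylic acid or a phenyl ring. They also leave open whether the amide hydrogen matters, which a methyl group in its place would test, so the similar results seen so far cannot be taken to mean that any group at this carbonyl carbon would do equally well.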